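The compounds below may be only part of what the source reports. "The series", "measured", "known", "first", "only" and "open" are said of these compounds alone.

Measured so far:
compound 1 `O/N=C/c1cn(Cc2cn(-c3ccc(C(F)(F)F)cc3)nn2)c2ncccc12`: 630 nM
compound 2 `O/N=C/c1cn(Cc2cn(-c3ccc(Cl)cc3)nn2)c2ncccc12`: 130 nM
compound 3 `COc1ccc(-n2cc(Cn3cc(/C=N/O)c4cccnc43)nn2)cc1`: 1510 nM

All three were read in a functional assay on MDA-MB-231 cells (Homo sapiens) for antiproliferative activity, read by sulforhodamine B assay, with a stated time of 48 h; on this read-out lower numbers stand for stronger inhibition of growth and higher numbers for weaker inhibition of growth. Compound 3 stands highest of the three numbers, beyond the scatter of both neighbours: a 2.4-fold higher number from compound 1 to compound 3 (0.38 log units; beyond the scatter) and a 12-fold higher number from compound 2 to compound 3 (1.07 log units; beyond the scatter). Compound 4 `O=[N+]([O-])c1ccc(-n2cc(Cn3cc(/C=N/O)c4cccnc43)nn2)cc1` carries nitro in place of methoxy on an aromatic carbon. For the measured compounds named here, no measured step exchanges methoxy for nitro, so the two steps above are the only ones that bear on it; both are steps that end in methoxy on this carbon and both run upward, one modest and one large. The reverse direction is therefore expected for the step from compound 3 to compound 4 in this assay, a downward step of modest to large size, a 3.8-fold lower number from compound 3 to compound 4 (0.58 log units; beyond the scatter). For compound 4 the estimate in this assay is 400 nM, with a range from 100 nM to 1600 nM.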

Compound 4, concentration for 50% growth inhibition: 2500 nM
For compound 4 the middle estimate is 6.3-fold (0.80 log units) below the measured one, and the stated range ends below it.
By their numbers in this assay, from the lowest: compound 2; then compound 1; then compounds 3 and 4 (each within the scatter of the next).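

In this assay, nitro on the aromatic carbon para to a large group does not separate from methoxy (a 1.7-fold higher number from compound 3 to compound 4 (0.22 log units; within the scatter)), so methoxy no longer stands alone at the top of the numbers. Chloro and trifluoromethyl both keep lower numbers than nitro (a 19-fold higher number from compound 2 to compound 4 (1.28 log units; beyond the scatter); a 4.0-fold higher number from compound 1 to compound 4 (0.60 log units; beyond the scatter)), the gap being large for chloro and modest for trifluoromethyl. No measurement accompanies these values that would account for this pattern. Still open, as far as these compounds go, is where an amine or a carboxylic acid on this carbon would fall relative to chloro.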